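A few compounds are considered here, and "the series" means these few. Any claim that something is new, unique, unknown or untested is made for them only; others in the source may bear on it.

Compounds measured so far in a functional assay on the whole organism with Rattus norvegicus as the target; on this read-out higher numbers stand for an effect only at larger amounts of compound and lower numbers for an effect already at smaller amounts:
compound 1 `C/C=C\C=C\[C@](C)(O)C/C=C/[C@H]1[C@H](O)CC(=O)[C@@H]1CC/C=C\CCC(=O)OC` gives 0.306 mg/kg;
compound 2 `C=C/C=C/[C@](C)(O)C/C=C/[C@H]1[C@H](O)CC(=O)[C@@H]1CC/C=C\CCC(=O)OC` gives 0.243 mg/kg;
compound 3 `CCCCC(C)(O)C/C=C/[C@H]1[C@H](O)CC(=O)[C@@H]1CC/C=C\CCC(=O)OC` gives 0.049 mg/kg.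

Compound 3 stands lowest of the three; the step of a 6.2-fold lower number from compound 1 to compound 3 (0.80 log units; beyond the scatter) and the step of a 5.0-fold lower number from compound 2 to compound 3 (0.70 log units; beyond the scatter) both lie beyond the scatter, whereas a 1.3-fold lower number from compound 1 to compound 2 (0.10 log units; within the scatter) does not.

Compound 4 `C/C=C/C=C/[C@](C)(O)C/C=C/[C@H]1[C@H](O)CC(=O)[C@@H]1CC/C=C\CCC(=O)OC` is still unmeasured. The change from compound 3 is 1-hydroxy-1-methylhexa-2,4-dien-1-yl in place of 1-hydroxy-1-methylpentyl on a saturated chain carbon bound to a double-bonded chain carbon. This reverses the kind of change seen in a 6.2-fold lower number from compound 1 to compound 3 (0.80 log units; beyond the scatter) and a 5.0-fold lower number from compound 2 to compound 3 (0.70 log units; beyond the scatter), so a modest step to a higher number is expected in this assay. Compound 4 is accordingly estimated at 0.28 mg/kg (range 0.12 mg/kg to 0.65 mg/kg), which means an expected step of a 5.7-fold higher number from compound 3 to compound 4 (0.76 log units; beyond the scatter).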

Compound 4, dose for half-maximal effect: 0.25 mg/kg
Estimate against measurement, compound 4: 1.1-fold (0.05 log units) above, within the range that was stated.
By their numbers in this assay, from the lowest: compound 3; then compounds 2, 4 and 1 (each within the scatter of the next).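

In this assay, the saturated 1-hydroxy-1-methylpentyl of compound 3 now stands apart from the E,E diene as well (a 5.1-fold higher number from compound 3 to compound 4 (0.71 log units; beyond the scatter)). Among the dienes, neither prop-1-en-1-yl in place of vinyl (a 1.0-fold higher number from compound 2 to compound 4 (0.01 log units; within the scatter)) nor the double-bond geometry (a 1.2-fold lower number from compound 1 to compound 4 (0.09 log units; within the scatter)) gives a step beyond the scatter. The second of these pairs tests geometry alone: the fact that compounds 1 and 4 differ only in the configuration as drawn.

Compound 3 has no defined stereocentre in this group, so saturation and configuration remain unseparated here. As far as these compounds go, how a phenyl ring in place of the diene would read also remains open.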